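Nitro for Chloro on a Chalcone Amide: Vero Toxicity

A few compounds are considered here, and "the series" means these few. Any claim that something is new, unique, unknown or untested is made for them only; others in the source may bear on it.

Measured compounds:
compound 1 `COC(=O)c1cc(-c2cccc(NC(=O)c3ccc(/C=C/C(=O)c4ccccc4Br)cc3)c2)on1`: > 40 ug/mL
compound 2 `COC(=O)c1cc(-c2cccc(NC(=O)c3ccc(/C=C/C(=O)c4ccccc4Cl)cc3)c2)on1`: > 25 ug/mL

In an ADME assay on Vero cells (Chlorocebus sabaeus) for cytotoxicity, read by MTT assay, with a stated time of 72 h (on this read-out higher numbers stand for lower toxicity in this test and lower numbers for higher toxicity in this test), compound 1 gives only a limit, > 40 ug/mL. In this assay compound 2 likewise gives only a limit, > 25 ug/mL. Both being limits, a step that the two limits leave unreadable from compound 1 to compound 2 has no readable size, which is all that the limit of > 25 ug/mL in this assay, at which 1 of the 2 values shown sits, and the limit of > 40 ug/mL in this assay, at which 1 of the 2 values shown sits, show. Compound 3 `COC(=O)c1cc(-c2cccc(NC(=O)c3ccc(/C=C/C(=O)c4ccc([N+](=O)[O-])cc4)cc3)c2)on1` differs from compound 2 by 4-nitrophenyl in place of 2-chlorophenyl on a carbonyl carbon. Within the data shown here, the single measured step offers no guide to a change of this kind, so no step beyond the scatter is expected, a step that the limit leaves unreadable from compound 2 to compound 3. Compound 3 is therefore estimated at 30 ug/mL, within 8 ug/mL to 100 ug/mL, and may again be reported only as a limit.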

Compound 3, half-maximal cytotoxic concentration: > 20 ug/mL
Compound 3: only a limit was reported (the forecaster's own chance of this, stated with the estimate: 55%); the middle value lies beyond the limit too.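

Among these compounds, compound 1, compound 2 and compound 3 all give only limits in this assay, and no step among them can be read. The compounds shown leave open whether 4-nitrophenyl in place of 2-chlorophenyl changes toxicity in this test at all.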